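Pyridin-3-ylmethyl replaces cyclohexyl on the ring nitrogen of compound 1

The source may hold more compounds than are shown below. What is called first, only, known or untested is meant among the compounds shown, and "the series" means these compounds.

Three compounds sharing a core were measured in a functional assay on MGC-803 cells (Homo sapiens) for antiproliferative activity, read by CCK-8 assay, with a stated time of 72 h, tested at 2 uM; a lower number here means a weaker effect, a higher number a stronger effect of the compound at the concentration tested. Compound 1 `Nc1ccccc1NC(=O)c1ccc(CSC(=S)N2CCN(C3CCCCC3)CC2)cc1` gives 16.9%, the lowest of the three numbers. Compound 2 `Nc1ccccc1NC(=O)c1ccc(CSC(=S)N2CCCc3ccccc32)cc1` gives 38.5%, and compound 3 `CN(C(=S)SCc1ccc(C(=O)Nc2ccccc2N)cc1)c1cccnc1` gives 46.1%; compound 1 therefore stands beyond the scatter below both, with compound 2 nearest and compound 3 furthest. For the measured compounds named here, the one step measured between neighbours, a number 7.6 percentage points higher from compound 2 to compound 3 (within the scatter), concerns the amine bound to the thiocarbonyl carbon and stays within the scatter.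

Compound 4 `Nc1ccccc1NC(=O)c1ccc(CSC(=S)N2CCN(Cc3cccnc3)CC2)cc1` has not yet been measured. It differs from compound 1 in one place: (pyridin-3-yl)methyl in place of cyclohexyl on an amine nitrogen in a ring. Going by the values given here, no measured step touches this amine nitrogen in a ring, so the outcome cannot be read off any measured pair. Among the compounds with values here, the only guidance is indirect: compound 3, which carries methyl(pyridin-3-yl)amino on a thiocarbonyl carbon, gives 46.1%, while compound 1 gives 16.9%; but those two differ in more than one place, and the single step on record, a number 7.6 percentage points higher from compound 2 to compound 3 (within the scatter), is itself within the scatter. The account therefore expects compound 4 to move by a number 6.1 percentage points higher from compound 1 to compound 4 (within the scatter), a shift that may not exceed the scatter. Compound 4 is estimated at 23%, in a range from 8% to 42%.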

Compound 4, a percentage reported as inhibition, at one concentration (the size of the read-out at that concentration, not a potency): 37.7%
The estimate for compound 4 lay 14.7 percentage points below the measured number; the measured number falls inside the stated range.
By their numbers in this assay, from the lowest: compound 1; then compounds 4, 2 and 3 (each within the scatter of the next).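

Exchanging cyclohexyl for (pyridin-3-yl)methyl on the amine nitrogen in a ring gives a number 20.8 percentage points higher from compound 1 to compound 4 (beyond the scatter) in this assay. For the compounds shown here, this is the first measured step at this place and, unlike the earlier step on the thiocarbonyl carbon, it lies beyond the scatter, so the read-out at this single concentration does respond to the group carried on this nitrogen. The change replaces a non-aromatic ring of carbon only with an aromatic ring holding a hetero atom and brings in a hydrogen-bond acceptor, but nothing measured here ties the rise to either feature or gives a reason for it.

The compounds shown leave open whether the rise belongs to the ring nitrogen of the pyridine, to the aromatic ring as such or to the connecting methylene, a question that benzyl, pyridin-4-ylmethyl or pyridin-3-yl set directly on the same nitrogen could help to separate. They also leave open how the step would translate into a potency, as the read-out comes from one concentration only.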